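Piperazine nitrogen substituent and histamine H2 receptor binding

The compounds below may be only part of what the source reports. "The series", "measured", "known", "first", "only" and "open" are said of these compounds alone.

Measured compounds:
compound 1 `CCCCCC(=O)c1ccc(OCCCN2CCN(C(=O)OC)CC2)cc1` — 12000 nM
compound 2 `CCCCCC(=O)c1ccc(OCCCN2CCN(C(=O)C(C)C)CC2)cc1` — 29500 nM

Among the compounds with values here, in an assay on isolated protein for binding affinity to histamine H2 receptor (Homo sapiens) (on this read-out lower numbers stand for stronger inhibition and higher numbers for weaker inhibition), compound 2 gives the higher of the two numbers, with a 2.5-fold higher number from compound 1 to compound 2 (0.39 log units; beyond the scatter) the only measured step. Compound 3 `CCCCCC(=O)c1ccc(OCCCN2CCN(CC3CC3)CC2)cc1` differs from compound 2 by cyclopropylmethyl in place of isopropylcarbonyl on an amine nitrogen in a ring. Within the data shown here, the single step from compound 1 to compound 2 bears on it only loosely, since it changed the carbonyl substituent, whereas here the carbonyl leaves the amine nitrogen altogether; no measured pair covers that change. For compound 3 a modest step in either direction, a 2.0-fold lower number from compound 2 to compound 3 (0.29 log units; within the scatter), is expected, with an estimate of 15000 nM and a range from 4000 nM to 60000 nM.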

Compound 3, inhibition constant: 18600 nM
Compound 3: the middle estimate sits 1.2-fold (0.09 log units) below what was measured, within the range that was stated.
By their numbers in this assay, from the lowest: compounds 1, 3 and 2 (each within the scatter of the next, the first and the last beyond it).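

In this assay, cyclopropylmethyl on the amine nitrogen in the ring leaves no carbonyl at this position, yet compound 3 is not separated from either carbonyl-bearing compound: the steps are a 1.6-fold lower number from compound 2 to compound 3 (0.20 log units; within the scatter) and a 1.6-fold higher number from compound 1 to compound 3 (0.19 log units; within the scatter). Removing the carbonyl therefore has no effect here that can be told from the scatter, and the side of this position that carries an oxygen is not shown to matter. Nothing available explains this result. Still open, going by these compounds, is whether a bare hydrogen, a benzyl group or a longer alkyl chain on this nitrogen would move the number beyond the scatter.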